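Working notes: cytotoxicity limits and a phenyl-to-hydrogen step

The source may hold more compounds than are shown below. What is called first, only, known or untested is meant among the compounds shown, and "the series" means these compounds.

Measured so far:
- Compound 1, `CCN(CC)CN1C(=O)/C(=N/NC(=S)Nc2ccccc2)c2cc(Cl)ccc21`: in an ADME assay on HeLa cells (Homo sapiens) for cytotoxicity (a higher number here means that more compound is tolerated, a lower number that less compound is tolerated), compound 1 gives >= 20000 nM, which is a limit of the assay and not a number.
- Compound 2, `CCN(CC)CN1C(=O)/C(=N/NC(=S)Nc2ccc(Cl)cc2)c2ccccc21`: in this assay compound 2 gives >= 4000 nM, again a limit of the assay rather than a number.

Within the data shown here, compound 1 therefore stands at the limit of >= 20000 nM in this assay, at which 1 of the 2 values shown sits; the only other value shown sits at the limit of >= 4000 nM in this assay, at which 1 of the 2 values shown sits. Among the measured compounds shown here, both compounds stop at a limit, so neither gives a number to compare, and no pair of measured compounds differing in one place is available, so no measured step size exists.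

Compound 3, `CCN(CC)CN1C(=O)/C(=N/NC(N)=S)c2cc(Cl)ccc21`, is not yet measured. It differs from compound 1 by hydrogen in place of phenyl on an amide-type nitrogen.

Since compound 1 sits at the limit of >= 20000 nM in this assay, at which 1 of the 2 values shown sits, with no cytotoxicity reached, the expectation for this change is a step of none beyond the scatter, most likely ending again at a limit. The expected step is a number no higher from compound 1 to compound 3 (the limit leaves the size open). Compound 3 is estimated at 20000 nM in this assay, with a range from 8000 nM to 50000 nM.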

Compound 3, minimum cytotoxic concentration: > 100000 nM
Compound 3 gave a limit, no number; the forecaster's own chance of this, stated with the estimate: 75%; middle value at least 5.0-fold (0.69 log units) from the limit.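

Compound 1 and compound 3 both stop at a limit in this assay, so no step can be read between them. Compound 3 gives > 100000 nM, a limit and not a number. The compounds shown leave open how large the effect of hydrogen in place of phenyl on this amide-type nitrogen is.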